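The source may hold more compounds than are shown below. What is called first, only, known or untested is meant among the compounds shown, and "the series" means these compounds.

Going by the values given here, in a functional assay on HeLa cells (Homo sapiens) for inhibition, read by CCK-8 assay, with a stated time of 72 h, tested at 2 uM (a higher number here means more inhibition of growth at the concentration tested, a lower number less inhibition of growth), compound 3 (`Cc1ccc(SCc2ccc(/C=C/C(=O)Nc3ccccc3N)cc2)cc1`) gives 25.5% and stands highest of the three measured so far, with compound 1 (`COc1ccc(SCc2ccc(/C=C/C(=O)Nc3ccccc3N)cc2)cc1OC`) at 10.1% and compound 2 (`Nc1ccccc1NC(=O)/C=C/c1ccc(CSc2cccc(F)c2)cc1`) at 2.25% in the same test. Compound 4 (`Nc1ccccc1NC(=O)/C=C/c1ccc(CSCCc2ccccc2)cc1`) differs from compound 3 at one place (phenethyl in place of 4-methylphenyl on a sulfur): phenethyl in place of 4-methylphenyl on a sulfur. Swaps at this same sulfur have given a number 15.4 percentage points higher from compound 1 to compound 3 (beyond the scatter) and a number 23.3 percentage points higher from compound 2 to compound 3 (beyond the scatter) as well as a number 7.9 percentage points lower from compound 1 to compound 2 (within the scatter) in the measured set. Among the compounds with values here, no measured compound carries phenethyl, and compound 3 at 25.5% already tops the set, so a modest fall seems likelier than a rise. In this assay the expected step is a number 12.5 percentage points lower from compound 3 to compound 4 (beyond the scatter) on this reasoning. Compound 4 is estimated at 13% (range 0% to 32%).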

Compound 4, percent growth inhibition at one concentration: 0.19%
The estimate for compound 4 lay 12.8 percentage points above the measured number, and the stated range covers the measured number.
By their numbers in this assay, from the lowest: compounds 4, 2 and 1 (each within the scatter of the next); then compound 3.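

In this assay, replacing the ring on the sulfur with phenethyl, which carries a chain before its ring, gives a number 25.3 percentage points lower from compound 3 to compound 4 (beyond the scatter) and shows that the 4-methylphenyl result does not carry over to this group. The other two comparisons, a number 2.1 percentage points lower from compound 2 to compound 4 (within the scatter) and a number 9.9 percentage points lower from compound 1 to compound 4 (within the scatter), place phenethyl level with 3-fluorophenyl and 3,4-dimethoxyphenyl, leaving compound 3 alone among these four compounds. No evidence here explains this difference. Still open, going by these compounds, is how a benzyl group, a longer chain or an amine at the end of the chain would behave on this sulfur.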